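The source may hold more compounds than are shown below. What is called first, only, known or untested is meant among the compounds shown, and "the series" means these compounds.

Measured compounds:
compound 1 `Cc1cccc(C(=O)N2CCCC(C(=O)Nc3ccc(Cl)cc3)C2)c1`: 0%
compound 2 `CC(C)(C)OC(=O)c1cccc(NC(=O)C2CCCN(C(=O)c3cc(C(F)(F)F)cc(C(F)(F)F)c3)C2)c1`: 0%

In an ADME assay on PC-3 cells (Homo sapiens) for cytotoxicity, read by WST assay, tested at 100 uM (on this read-out lower numbers stand for less inhibition and higher numbers for more inhibition at the one concentration tested (going by the name of the read-out)), compound 1 gives 0%, so at the single concentration tested it leaves the cells untouched. Compound 2 gives 0% in this assay, level with compound 1 at the digits shown; these two differ in several places at once, so all that can be said is that their two values agree within the usual scatter. Compound 3 `CC(C)(C)CC(=O)Nc1cccc(C(=O)N2CCCC(C(=O)Nc3ccc(Cl)cc3)C2)c1` has not yet been measured. It differs from compound 1 in one place: (neopentylcarbonyl)amino in place of methyl on an aromatic carbon. For the measured compounds named here, no step between two measured compounds is known here, so the size of this step can only be expected, not read off another pair. Both measured compounds show no inhibition at all, and nothing in the data points to the new group changing that. The step from compound 1 to compound 3 is therefore expected to be a number 3 percentage points higher from compound 1 to compound 3 (within the scatter), none beyond the scatter. Compound 3 is expected to give 3% in this assay, with a range from 0% to 15%.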

Compound 3, a percentage reported as inhibition, at one concentration (the size of the read-out at that concentration, not a potency): 0%
The estimate for compound 3 lay 3 percentage points above the measured number; the measured number falls inside the stated range.
By their numbers in this assay, from the lowest: compounds 1, 2 and 3 (each within the scatter of the next).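

In this assay, putting (neopentylcarbonyl)amino in place of methyl on an aromatic carbon, meta to a large group, gives no change at the digits printed from compound 1 to compound 3 (within the scatter). This is the first single change in the series, and it shows that a group of eight heavy atoms, carrying a hydrogen-bond donor and a hydrogen-bond acceptor, can stand at this position without any inhibition of the cells appearing at the one concentration tested; since compound 1 already gives 0%, only a rise could have shown here, and none did. Nothing available explains why the read-out stays the same after this change.

The compounds shown leave open whether an amine, a carboxylic acid or a longer carbon chain at the same position would also leave the read-out unchanged. They also leave open whether the same change would give the same result on compound 2, whose other groups differ from those of compound 1 in several places.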